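Adding a chloro group to compound 3

The compounds below may be only part of what the source reports. "The series", "measured", "known", "first", "only" and "open" are said of these compounds alone.

Measured in a functional assay on U-251 cells (Homo sapiens); on this read-out higher numbers stand for weaker inhibition of growth and lower numbers for stronger inhibition of growth:
- Compound 1 `O=S(=O)(/C=C/c1ccc(Cl)cc1)Cc1ccc(Nc2ncnc3ccccc23)cc1`: 49000 nM
- Compound 2 `O=S(=O)(/C=C/c1ccc(Cl)c(Cl)c1)Cc1ccc(Nc2ncnc3ccc(Br)cc23)cc1`: > 100000 nM, a limit of the assay and not a number
- Compound 3 `O=S(=O)(/C=C/c1ccc(Cl)cc1)Cc1ccc(Nc2ncnc3ccc(Br)cc23)cc1`: 30000 nM

In this assay, compound 3 gives 30000 nM, and it stands within the scatter of compound 1. Among the compounds with values here, compound 2 is the only compound reported at a limit.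

Compound 4 `O=S(=O)(/C=C/c1ccc(Cl)cc1Cl)Cc1ccc(Nc2ncnc3ccc(Br)cc23)cc1` differs from compound 3 by chloro in place of hydrogen on an aromatic carbon. This is chloro in place of hydrogen on an aromatic carbon, ortho to a large group and meta to a chloro group, so that 4-chlorophenyl becomes 2,4-dichlorophenyl.

Two measured steps are available. The one that bears most closely is an at least 3.3-fold lower number from compound 2 to compound 3 (0.52 log units; beyond the scatter), since it also concerns a chloro on that aromatic ring, though at a different place. The other, a 1.6-fold lower number from compound 1 to compound 3 (0.21 log units; within the scatter), concerns bromo at another part of the molecule and says little here. On the evidence of compound 2, a higher number is expected for compound 4, meaning weaker inhibition of growth, and a modest rise rather than a large one. The expected change is a 2.0-fold higher number from compound 3 to compound 4 (0.30 log units; within the scatter). For compound 4 the estimated value is 60000 nM, with an expected range of 25000 nM to 140000 nM.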

Compound 4, concentration for 50% growth inhibition: 4000 nM
Beside the measured number, compound 4's estimate is 15-fold (1.18 log units) above it, outside the stated range (below it).
By their numbers in this assay, from the lowest: compound 4; then compounds 3 and 1 (each within the scatter of the next). At a limit, above all of these: compound 2.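

In this assay, a second chloro on the 4-chlorophenyl ring does not have to weaken growth inhibition: placed ortho to a large group to give 2,4-dichlorophenyl, it brings a 7.5-fold lower number from compound 3 to compound 4 (0.88 log units; beyond the scatter) as its result. The earlier compounds shown here showed a second chloro only in the 3,4-dichlorophenyl arrangement, and there compound 2 has > 100000 nM as its entry, a limit of the assay and not a number. Among these compounds, the place of the second chloro therefore sets the direction of the change, and the two dichlorophenyl arrangements are separated by an at least 25-fold lower number from compound 2 to compound 4 (1.39 log units; beyond the scatter) as a bound on the size, not an exact gap: the limit of > 100000 nM in this assay, at which 1 of the 4 values shown sits.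

The compounds shown leave open whether this drop belongs to chloro itself or would also come with a fluoro, a methyl or a methoxy group at the same place on the ring. They also leave open whether the 2,4-dichlorophenyl group would give a similar step on the core without the bromo group, the core of compound 1.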